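The source may hold more compounds than are shown below. What is called first, only, known or untested is meant among the compounds shown, and "the series" means these compounds.

Among the compounds with values here, compound 2 `Nc1nc(OCC2CC2)c2ncn(C3CC(O)C(CO)S3)c2n1` stands highest of the two numbers so far in a functional assay on IM-9 cells (Homo sapiens) for cytotoxicity (on this read-out higher numbers stand for lower toxicity in this test and lower numbers for higher toxicity in this test), at 61000 nM and compound 1 `COc1nc(N)nc2c1ncn2C1CC(O)C(CO)S1` lies lower at 5000 nM in the same test. The change to compound 3 `Nc1nc(O)c2ncn(C3CC(O)C(CO)S3)c2n1` is hydrogen in place of cyclopropylmethyl on an oxygen on an aromatic ring and amounts to hydrogen in place of cyclopropylmethyl on an oxygen on an aromatic ring. Within the data shown here, only one measured step bears on it: a 12-fold higher number from compound 1 to compound 2 (1.09 log units; beyond the scatter) is large and beyond the scatter, with the smaller group on the lower number. A similar or larger step towards a lower number is therefore expected in this assay on this single pair. The expected step is a 31-fold lower number from compound 2 to compound 3 (1.48 log units; beyond the scatter) in this estimate. Compound 3 is estimated at 2000 nM with 300 nM to 15000 nM as the expected range.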

Compound 3, half-maximal cytotoxic concentration: 4000 nM
Compound 3: the middle estimate sits 2.0-fold (0.30 log units) below what was measured, and the stated range covers the measured number.
By their numbers in this assay, from the lowest: compounds 3 and 1 (each within the scatter of the next); then compound 2.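

In this assay, hydrogen in place of cyclopropylmethyl on the oxygen gives a 15-fold lower number from compound 2 to compound 3 (1.18 log units; beyond the scatter) and so removes the high number of compound 2, while hydrogen in place of methyl gives only a 1.3-fold lower number from compound 1 to compound 3 (0.10 log units; within the scatter) and leaves no readable change. Among these three compounds, only cyclopropylmethyl separates from the rest at this position, and hydroxy and methoxy cannot be told apart. Nothing at hand explains the difference. Still open, from the compounds shown here alone, is whether a straight butyl chain on the oxygen would match cyclopropylmethyl. Also open, going by these compounds, is how an amine in place of that oxygen would read.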